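Amide nitrogen substituent on the chain: compound 3 to compound 4

The source may hold more compounds than are shown below. What is called first, only, known or untested is meant among the compounds shown, and "the series" means these compounds.

Measured compounds:
compound 1 `C=CC[C@@H]1C[C@@H](c2ccc(Cl)c(Cl)c2)[C@H](NC(=O)c2cc(-c3c(Cl)cnn3C)c(Cl)o2)CN1`: 160 nM
compound 2 `Cn1ncc(Cl)c1-c1cc(C(=O)N[C@@H]2CN[C@H](CCN3CCCC3)C[C@H]2c2ccc(Cl)c(Cl)c2)oc1Cl`: 1920 nM
compound 3 `Cn1ncc(Cl)c1-c1cc(C(=O)N[C@@H]2CN[C@H](CC(=O)NCC(O)CO)C[C@H]2c2ccc(Cl)c(Cl)c2)oc1Cl`: 660 nM

Three compounds share one core and differ only in the group on a saturated chain carbon bound to a saturated ring carbon. In a functional assay on LNCaP cells (Homo sapiens) for antiproliferative activity (on this read-out higher numbers stand for weaker inhibition and lower numbers for stronger inhibition), compound 1 gives 160 nM, compound 2 gives 1920 nM and compound 3 gives 660 nM. Compound 3 stands second highest of the three numbers: a 4.1-fold higher number from compound 1 to compound 3 (0.62 log units; beyond the scatter), while a 2.9-fold lower number from compound 2 to compound 3 (0.46 log units; beyond the scatter). The largest step seen is a 12-fold higher number from compound 1 to compound 2 (1.08 log units; beyond the scatter).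

Compound 4 `Cn1ncc(Cl)c1-c1cc(C(=O)N[C@@H]2CN[C@H](CC(=O)NC3CCC3)C[C@H]2c2ccc(Cl)c(Cl)c2)oc1Cl` keeps the carbamoyl chain of compound 3 and changes only its amide nitrogen substituent: cyclobutyl in place of 2,3-dihydroxypropyl on an amide-type nitrogen.

None of the three measured steps touches the amide nitrogen; all of them exchange the whole group on the chain carbon. Going by the values given here, no measured step therefore bears directly on this change. The nearest guide is that compound 3 and compound 2 differ modestly while both sit well above compound 1, so a step of modest size at most is expected in this assay, with the direction uncertain. The expected step is a 1.3-fold lower number from compound 3 to compound 4 (0.12 log units; within the scatter). Compound 4 is estimated at 500 nM, within 200 nM to 1500 nM.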

Compound 4, half-maximal inhibitory concentration: 80 nM
Compound 4: the middle estimate sits 6.3-fold (0.80 log units) above what was measured, and the stated range ends above it.
By their numbers in this assay, from the lowest: compounds 4 and 1 (each within the scatter of the next); then compound 3; then compound 2.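

In this assay, the amide nitrogen substituent matters on its own: cyclobutyl in place of 2,3-dihydroxypropyl gives a step beyond the scatter (an 8.3-fold lower number from compound 3 to compound 4 (0.92 log units; beyond the scatter)), so keeping the carbamoyl chain does not fix the read-out. Cyclobutylcarbamoyl in place of (pyrrolidin-1-yl)methyl gives the largest step in the set so far (a 24-fold lower number from compound 2 to compound 4 (1.38 log units; beyond the scatter)), while in place of vinyl it stays within the scatter (a 2.0-fold lower number from compound 1 to compound 4 (0.30 log units; within the scatter)), so compound 4 and compound 1 cannot be ordered. Nothing at hand explains these steps.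

As far as these compounds go, it remains open whether the ring of cyclobutyl or the loss of the hydroxyl groups carries the step. An open-chain butyl, a cyclopentyl or a hydroxycyclobutyl on the same amide nitrogen would help separate the two.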